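Piperidine amide variation at the 2-position of the core

A few compounds are considered here, and "the series" means these few. Any claim that something is new, unique, unknown or untested is made for them only; others in the source may bear on it.

Measured so far in an assay on isolated protein for displacement of a labelled ligand from Adrenergic receptor alpha-1 (Rattus norvegicus); a higher number here means a weaker inhibitor, a lower number a stronger inhibitor:
compound 1 `CCNC(=O)C1CCN(c2nc(N)c3cc(OC)c(OC)cc3n2)CC1` gives 1.64 nM;
compound 2 `COc1cc2nc(N3CCC(C(=O)NC4CCCC4)CC3)nc(N)c2cc1OC` gives 0.63 nM;
compound 3 `COc1cc2nc(N3CCC(C(=O)Nc4ccccc4)CC3)nc(N)c2cc1OC` gives 0.47 nM.

Compound 3 has the lowest number of the three. Its gap to compound 2 is within the scatter, so the two cannot be ordered; its gap to compound 1 is beyond the scatter, as the step of a 3.5-fold lower number from compound 1 to compound 3 (0.54 log units; beyond the scatter) shows.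

Compound 4 `COc1cc2nc(N3CCC(CC(=O)NCC4CC4)CC3)nc(N)c2cc1OC` is not yet measured. Relative to compound 3 the change is ((cyclopropylmethyl)carbamoyl)methyl in place of phenylcarbamoyl on a saturated ring carbon. Within the data shown here, two measured steps bear on the nature of the amide substituent: the step of a 3.5-fold lower number from compound 1 to compound 3 (0.54 log units; beyond the scatter) and the step of a 1.3-fold lower number from compound 2 to compound 3 (0.13 log units; within the scatter). Moving from phenyl to a small alkyl group gave a modest rise in number, while moving to a larger saturated ring gave none beyond the scatter. Cyclopropylmethyl sits between ethyl and cyclopentyl in size. Among the measured compounds shown here, no measured step covers the added carbon between the ring and the carbonyl. A modest rise in number, or none beyond the scatter, is therefore expected for compound 4, with the step of a 2.6-fold higher number from compound 3 to compound 4 (0.41 log units; beyond the scatter) as the working estimate. Compound 4 is estimated at 1.2 nM, within the range 0.5 nM to 3 nM.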

Compound 4, inhibition constant: 1.08 nM
The estimate for compound 4 lay 1.1-fold (0.05 log units) above the measured number; low and high end bracket the measured number.
By their numbers in this assay, from the lowest: compounds 3, 2, 4 and 1 (each within the scatter of the next, the first and the last beyond it).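

In this assay, ((cyclopropylmethyl)carbamoyl)methyl in place of phenylcarbamoyl on the saturated ring carbon gives a 2.3-fold higher number from compound 3 to compound 4 (0.36 log units; beyond the scatter), a modest step, so this position still accepts a group of this extended form with a three-membered ring instead of the six-membered aromatic ring. Against the two alkyl amides the gaps are a 1.7-fold higher number from compound 2 to compound 4 (0.23 log units; within the scatter) and a 1.5-fold lower number from compound 1 to compound 4 (0.18 log units; within the scatter), so the extended group cannot be ordered against cyclopentylcarbamoyl or ethylcarbamoyl. No evidence on hand accounts for these steps.

The change alters the chain on the ring carbon and the group on the amide nitrogen together, and the compounds shown do not separate the two contributions. On these data alone, how a longer chain, a carboxylic acid or an amine at this ring carbon would read in this assay remains open.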